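From compound 3 to compound 4: a sulfonyl swap

The source may report more compounds than this note shows. Statements on the series, on what has been measured and on what is new or still open speak of the compounds shown alone.

Of the compounds shown here, three with a shared core have been measured in an ADME assay on microsomes from liver (Mus musculus) for metabolic stability, read by LC-MS, with a stated time of 30 min, tested at 1 uM; a lower number here means that less of the compound is left, a higher number that more of the compound is left. Compound 1 `O=C(NCc1ccc(S(=O)(=O)c2cccc(F)c2)cc1)c1cc2cnccc2[nH]1` gives 44%, compound 2 `O=C(NCc1ccc(S(=O)(=O)c2ccccc2C(F)(F)F)cc1)c1cc2cnccc2[nH]1` gives 41% and compound 3 `Cc1cccc(S(=O)(=O)c2ccc(CNC(=O)c3cc4cnccc4[nH]3)cc2)c1` gives 32%. Two measured steps show where that last number stands. One is a number 12 percentage points lower from compound 1 to compound 3 (beyond the scatter), and the other is a number 9 percentage points lower from compound 2 to compound 3 (within the scatter). The last of the three compounds is therefore clearly separated from only one of the others.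

Compound 4 `O=C(NCc1ccc(S(=O)(=O)c2ccc(F)cc2)cc1)c1cc2cnccc2[nH]1` has not yet been measured. It carries 4-fluorophenyl in place of 3-methylphenyl on a sulfonyl sulfur.

The closest guide is compound 1, which has a 3-fluorophenyl group and gives 44%. Its step to the methyl-bearing compound is a number 12 percentage points lower from compound 1 to compound 3 (beyond the scatter), and the change planned here runs the opposite way, from methyl-bearing to fluoro-bearing, so a rise of similar size seems reasonable. The step of a number 3 percentage points lower from compound 1 to compound 2 (within the scatter) adds only a little, although it shows one further group swap on the sulfonyl sulfur staying within the scatter. Going by the values given here, no measured pair shows what a different fluoro placement does, so the range stays wide.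

The expected change is a number 10 percentage points higher from compound 3 to compound 4 (within the scatter), close to the edge of the scatter. For compound 4 the estimate is 42%, with an expected range from 29% to 55%.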

Compound 4, percent of the compound remaining: 72%
Beside the measured number, compound 4's estimate is 30 percentage points below it, outside the stated range (above it).
By their numbers in this assay, from the lowest: compounds 3, 2 and 1 (each within the scatter of the next, the first and the last beyond it); then compound 4.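

On a sulfonyl sulfur, the choice of aromatic group can matter far more in this assay than the first three compounds suggested: the change to 4-fluorophenyl gives a number 40 percentage points higher from compound 3 to compound 4 (beyond the scatter) and a number 31 percentage points higher from compound 2 to compound 4 (beyond the scatter) and so opens a much wider spread than those compounds showed among themselves. The most telling comparison is a number 28 percentage points higher from compound 1 to compound 4 (beyond the scatter) with 4-fluorophenyl in place of 3-fluorophenyl, two groups that carry the same atoms and differ only in where the fluorine sits on the ring, so having a fluorine on this ring is not enough on its own to give the high number. Nothing available here explains why this one change has so large an effect.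

The compounds shown leave open whether the rise depends on fluorine itself or on any group placed as in 4-fluorophenyl, a question that 4-chlorophenyl or 4-methylphenyl on the same sulfonyl sulfur would help to answer. They also leave open whether 2-fluorophenyl would stay with the lower numbers or join compound 4 at the top of this series.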